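The compounds below may be only part of what the source reports. "The series", "measured", "known", "first", "only" and "open" are said of these compounds alone.

Compound 1 `O=C(CCCCCNc1c(NCc2ccccc2)c(=O)c1=O)NO`: 5700000 nM
Compound 2 `C[C@H](Nc1c(NCCCCCC(=O)NO)c(=O)c1=O)c1ccccc1`: 28000000 nM
Compound 3 `CN(C)c1ccc(Nc2c(NCCCCCC(=O)NO)c(=O)c2=O)cc1`: 1400000 nM

These three compounds were tested in a physicochemical assay for solubility, with a stated time of 24 h, tested at 30 mg/mL; on this read-out higher numbers stand for higher solubility and lower numbers for lower solubility. Compound 1 gives 5700000 nM and compound 2 gives 28000000 nM. The two differ in one place, (methyl in place of hydrogen on a saturated chain carbon bound to an aromatic carbon and a nitrogen on an aromatic ring), and that change made a step of a 4.9-fold higher number from compound 1 to compound 2 (0.69 log units; beyond the scatter). Compound 3 gives 1400000 nM, the lowest of the three numbers. The difference between the core of compound 3 and the core of compound 1 is not broken down here.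

Compound 4 `C[C@H](CCCCC(=O)NO)Nc1c(Nc2ccc(N(C)C)cc2)c(=O)c1=O` has not yet been measured. It differs from compound 3 by methyl in place of hydrogen on a saturated chain carbon bound to a nitrogen on an aromatic ring and a saturated chain carbon. Among the measured compounds shown here, this is the same kind of change as the one from compound 1 to compound 2, a methyl entering where a hydrogen leaves, but it is not the same change: in compound 2 the carbon that carries the methyl is bound to an aromatic carbon and a nitrogen on an aromatic ring, while in compound 4 that carbon is bound to a nitrogen on an aromatic ring and a saturated chain carbon. Only one measured example of this kind of change exists among these compounds, so any expectation rests on that single step.

Because the earlier step of a 4.9-fold higher number from compound 1 to compound 2 (0.69 log units; beyond the scatter) went upward, a rise is expected for compound 4 as well, estimated at a 2.5-fold higher number from compound 3 to compound 4 (0.40 log units; beyond the scatter). Compound 4 is thus estimated at 3500000 nM, with a likely range from 1200000 nM to 12000000 nM.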

Compound 4, solubility: 27000000 nM
Compound 4: middle estimate off by 7.7-fold (0.89 log units), on the low side, and the stated range ends below it.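

In this assay, a methyl in place of a hydrogen on a saturated chain carbon bound to a nitrogen on an aromatic ring and a saturated chain carbon goes with a 19-fold higher number from compound 3 to compound 4 (1.29 log units; beyond the scatter), and this large step points the same way as the modest one seen earlier on a different core, a 4.9-fold higher number from compound 1 to compound 2 (0.69 log units; beyond the scatter). So the direction of this kind of change held in both of the cases shown, but its size did not carry over, and two steps are too few to make a rule, especially as the methyl sits on a differently bound carbon in each case. No measurement shown here explains why the number rises in either case or why the two steps differ in size.

The compounds shown leave open whether the same methyl placed on the matching chain carbon of compound 1 would also go with a higher number, which would separate the effect of the core from that of the carbon carrying the methyl. They also leave open whether a larger group on that carbon, such as an ethyl, or a different one, such as a hydroxyl, would move the number the same way.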